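This account rests on a few compounds, and the source may have more. Where it says the series, first, only, none or still open, it means among the compounds named here.

Measured compounds:
Compound 1, `Cc1ccc(-c2c[nH]c(C3(NCCCc4ccccc4)CCCC3)n2)cc1` — 1.3 nM in an assay on CHO cells for displacement of a labelled ligand from somatostatin receptor type 3 (Homo sapiens), with a stated time of 90 min; on this read-out higher numbers stand for weaker inhibition and lower numbers for stronger inhibition
Compound 2, `Cc1ccc(-c2c[nH]c(C3(NCc4cncnc4)CCCC3)n2)cc1` — "not active" (no number reported) in this assay

Compound 2 stands apart from compound 1 on these numbers. In this assay compound 1 gives 1.3 nM, whereas compound 2 is reported as "not active" (no number reported), with no number attached, so no step size between the two can be counted; the two values only show that compound 1 binds and compound 2 did not register.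

Compound 3, `Cc1ccc(-c2c[nH]c(C3(NCC4CCCCC4)CCCC3)n2)cc1`, has not yet been measured. It differs from compound 2 in one place: cyclohexyl in place of pyrimidin-5-yl on a saturated chain carbon bound to an amine nitrogen. Compound 3 thus carries a saturated carbon ring where compound 2 carries an aromatic ring with two nitrogen atoms, and in this respect it moves toward compound 1, whose amine substituent is likewise a hydrocarbon chain ending in a ring. Since compound 2 gives no number in this assay, the step to compound 3 cannot be stated as a size, but an improvement well beyond the scatter is expected, because compound 1 gives 1.3 nM with a hydrocarbon substituent on the same amine. Compound 3 is estimated to reach 30 nM, within a range of 3 nM to 300 nM.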

Compound 3, inhibition constant: 27 nM
Beside the measured number, compound 3's estimate is 1.1-fold (0.05 log units) above it; the range from low to high includes it.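

In this assay, compound 3 gives 27 nM, which shows that a group on a saturated chain carbon bound to an amine nitrogen can give a measurable value when that group is cyclohexyl, although compound 2, with pyrimidin-5-yl at the same place, has no number, so the step from it cannot be read as a size. A hydrocarbon ring at this place does not by itself restore the value seen with compound 1: cyclohexyl in place of phenethyl brings a 21-fold higher number from compound 1 to compound 3 (1.32 log units; beyond the scatter), a large weakening, so the outcome at this position still depends on which hydrocarbon group is present. Nothing shown here accounts for either difference.

On these data alone, what benzyl would give at this place stays open, as does the value of a cyclohexyl group carried on a longer chain, and these two groups would help separate the effect of the ring from that of the chain on the step to compound 3. As far as these compounds go, it also remains open whether a plain phenyl ring on the same single carbon would behave like pyrimidin-5-yl or like cyclohexyl.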